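Swapping Methoxy for Methanesulfonamido on a Shared Core

The source may hold more compounds than are shown below. What is called first, only, known or untested is meant among the compounds shown, and "the series" means these compounds.

Compound 1 `COc1c(C)ccc2c1CCC2c1ncc[nH]1` is the starting point. Going by the values given here, in a functional assay on CHO cells for agonist activity at Alpha-1A adrenergic receptor (Homo sapiens), read by FLIPR and calcium flux (on this read-out higher numbers stand for an effect only at larger amounts of compound and lower numbers for an effect already at smaller amounts), compound 1 gives 167 nM, the second highest of the three numbers measured so far. Compound 2 `COc1cccc2c1CCC2c1ncc[nH]1` differs from it only by carrying a hydrogen where compound 1 carries a methyl on the aromatic ring; compound 2 gives 32 nM, and the change amounts to a 5.2-fold lower number from compound 1 to compound 2 (0.72 log units; beyond the scatter). Compound 3 `CNC(=O)c1cccc2c1CCC2c1ncc[nH]1` carries methylcarbamoyl where compound 2 carries methoxy; compound 3 gives 2200 nM, and that change amounts to a 69-fold higher number from compound 2 to compound 3 (1.84 log units; beyond the scatter).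

Compound 4 `Cc1ccc2c(c1NS(C)(=O)=O)CCC2c1ncc[nH]1` has not yet been measured. It differs from compound 1 in a single place: methanesulfonamido in place of methoxy on an aromatic carbon. Among the compounds with values here, the measured step that bears most on this change is the one from compound 2 to compound 3, where the methoxy also gave way to a larger group bearing a hydrogen on nitrogen and the number rose by a large amount. The step from compound 1 to compound 2 concerns the methyl, which compound 4 keeps, so it bears less. A large rise is therefore expected for compound 4, a 24-fold higher number from compound 1 to compound 4 (1.38 log units; beyond the scatter). Compound 4 is expected to give about 4000 nM in this assay, within a range from 700 nM to 20000 nM.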

Compound 4, half-maximal effective concentration: 33 nM
Compound 4: middle estimate off by 120-fold (2.08 log units), on the high side; measured number outside the range, below it.
By their numbers in this assay, from the lowest: compounds 2 and 4 (each within the scatter of the next); then compound 1; then compound 3.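

In this assay, methanesulfonamido in place of methoxy gives a 5.1-fold lower number from compound 1 to compound 4 (0.70 log units; beyond the scatter) and so shows that, on this aromatic carbon ortho to a methyl group, a larger group with a hydrogen on nitrogen can go with a lower number. The earlier replacement of methoxy by methylcarbamoyl went the other way, with a 69-fold higher number from compound 2 to compound 3 (1.84 log units; beyond the scatter) on a core without the methyl, so carrying a hydrogen on nitrogen and being larger than methoxy does not by itself set the direction of the change. No supporting information is available to explain why the number fell here.

The two replacements differ both in the group that enters and in the presence of the methyl, so the compounds shown cannot separate these two influences. From the compounds shown here alone, it also remains open how this position would respond to a plain amine, a hydroxyl group or a carboxylic acid, and whether a longer chain on the sulfonyl group would keep the number this low.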